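The source may hold more compounds than are shown below. What is called first, only, known or untested is meant among the compounds shown, and "the series" means these compounds.

Of the compounds shown here, three sharing one core have been tested in a functional assay on the whole organism with Rattus norvegicus as the target; on this read-out lower numbers stand for an effect already at smaller amounts and higher numbers for an effect only at larger amounts of compound. Compound 1 `C=CCn1c(=N)sc2cc(OC(F)(F)F)ccc21` gives 7 mg/kg and compound 2 `N#CCn1c(=N)sc2cc(OC(F)(F)F)ccc21` gives 3.5 mg/kg, and the change between them is a 2.0-fold lower number from compound 1 to compound 2 (0.30 log units; within the scatter). Compound 3 `N=c1sc2cc(OC(F)(F)F)ccc2n1CC(=O)O` gives > 10 mg/kg in this assay, and this is a limit of the assay and not a number. Compound 3 is thus the only one of the three without a numerical value.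

The next compound, compound 4 `CSCn1c(=N)sc2cc(OC(F)(F)F)ccc21`, has methylsulfanyl in place of carboxy on a saturated chain carbon bound to an aromatic nitrogen.

For the measured compounds named here, two measured steps bear on this change, since both introduce the carboxy group that compound 4 gives up. The first is an at least 1.4-fold higher number from compound 1 to compound 3 (0.15 log units; that floor lies within the scatter), and the second is an at least 2.8-fold higher number from compound 2 to compound 3 (0.45 log units; beyond the scatter). On these data alone, only the second is firmly beyond the scatter, and both rest on a limit, so their true sizes remain open. Removing the carboxy group is expected to reverse them, giving a modest move towards lower numbers and a result in the region of compound 1 and compound 2. The expected change is an at least 2.0-fold lower number from compound 3 to compound 4 (0.30 log units; that floor lies within the scatter). For compound 4 the estimated value is 5 mg/kg, with an expected range from 2 mg/kg to 10 mg/kg.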

Compound 4, dose for half-maximal effect: 3 mg/kg
The estimate for compound 4 lay 1.7-fold (0.22 log units) above the measured number, within the range that was stated.
By their numbers in this assay, from the lowest: compounds 4, 2 and 1 (each within the scatter of the next, the first and the last beyond it). At a limit, above all of these: compound 3.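

In this assay the step away from the carboxy group is an at least 3.3-fold lower number from compound 3 to compound 4 (0.52 log units; beyond the scatter), and this size is only a floor, as compound 3 stands at a limit and not at a number: the limit of > 10 mg/kg in this assay, at which 1 of the 4 values shown sits. Among the compounds with numerical values, this position now shows its first step beyond the scatter, a 2.3-fold lower number from compound 1 to compound 4 (0.37 log units; beyond the scatter), whereas the earlier 2.0-fold lower number from compound 1 to compound 2 (0.30 log units; within the scatter) stayed within it. The cyano and methylsulfanyl groups, however, cannot be told apart at this position, with a 1.2-fold lower number from compound 2 to compound 4 (0.07 log units; within the scatter), so two different groups on the saturated chain carbon bound to an aromatic nitrogen give results within the scatter of each other.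

How far the carboxy step truly reaches remains open, since compound 3 has only a limit, and the shown values do not say what sets the numbers at this position. On these data alone, it also remains open whether an amine, an amide or a longer chain on this carbon would stay with compound 2 and compound 4 or move towards compound 3.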